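Swapping Cyano for Trifluoromethyl in a Cell Tolerance Test

The source may report more compounds than this note shows. Statements on the series, on what has been measured and on what is new or still open speak of the compounds shown alone.

In an ADME assay on MDCK cells (Canis lupus familiaris) for cytotoxicity, read by MTT assay, with a stated time of 24 h (a lower number here means that less compound is tolerated, a higher number that more compound is tolerated), compound 3 `N#CCCN(Cc1cccs1)S(=O)(=O)c1ccc(C#N)cc1` reads > 201000 nM as a limit only, not a number. Compound 1 `N#CCCN(Cc1cccs1)S(=O)(=O)c1ccc(Br)cc1` likewise gives > 173000 nM as a limit. Compound 2 `Cc1ccc(S(=O)(=O)N(CCC#N)Cc2cccs2)cc1` alone has a measured number (127000 nM). Compound 4 `N#CCCN(Cc1cccs1)S(=O)(=O)c1ccc(C(F)(F)F)cc1` carries trifluoromethyl in place of cyano on an aromatic carbon, para to a large group (trifluoromethyl in place of cyano on an aromatic carbon). Three measured swaps at that carbon bear on this change: one is unreadable (a step that the two limits leave unreadable from compound 1 to compound 3) and the floors of the others stay within the scatter (an at least 1.3-fold lower number from compound 1 to compound 2 (0.13 log units; that floor lies within the scatter) and an at least 1.5-fold higher number from compound 2 to compound 3 (0.19 log units; that floor lies within the scatter)) so this assay should show no step beyond the scatter for compound 4. The expected change is small (an at least 1.1-fold lower number from compound 3 to compound 4 (0.07 log units; that floor lies within the scatter)). Compound 4 is estimated at 170000 nM with an expected range from 100000 nM to 250000 nM for its coming measurement.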

Compound 4, half-maximal cytotoxic concentration: > 178000 nM
Compound 4 gave a limit, no number; the forecaster's own chance of this, stated with the estimate: 60%; middle value at least 1.0-fold (0.01 log units) away from the limit.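

In this assay, for the compounds shown here, trifluoromethyl on this aromatic carbon joins bromo and cyano in giving a limit rather than a number, leaving compound 2, with methyl, as the only compound with a measured value. Going by these compounds alone, the one readable step is an at least 1.4-fold higher number from compound 2 to compound 4 (0.14 log units; that floor lies within the scatter) and no more than that can be said of it. The steps to compound 4 from compound 1 and from compound 3 cannot be read, because both ends of each are limits: the limit of > 178000 nM in this assay, at which 1 of the 4 values shown sits.

On these data alone, how far each limit lies from a real number stays open. So does whether an amine or a carboxylic acid on this carbon would give a measured value in this assay at all.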